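The compounds below may be only part of what the source reports. "The series", "measured", "known", "first", "only" and "open" are said of these compounds alone.

Going by the values given here, in a functional assay on MKN-45 cells (Homo sapiens) for inhibition, with a stated time of 72 h (a lower number here means a stronger inhibitor, a higher number a weaker inhibitor), compound 1 (`COc1ccc(S(=O)(=O)N2CCc3cccc(-c4ccc(F)c(F)c4)c32)cc1`) gives 55.5 nM, the lower of the two numbers so far, and compound 2 (`COc1ccc(S(=O)(=O)N2CCc3cccc(-c4cc(OC)c(OC)c(OC)c4)c32)cc1`) gives 1080 nM, a gap beyond the scatter. The next entry is compound 3 (`COc1ccc(S(=O)(=O)N2CCc3cccc(-c4ccc(O)cc4)c32)cc1`), with this change from compound 1: 4-hydroxyphenyl in place of 3,4-difluorophenyl on an aromatic carbon. It places 4-hydroxyphenyl in place of 3,4-difluorophenyl on an aromatic carbon, ortho to a fused ring and meta to a fused ring. Among the compounds with values here, no measured step isolates this change, so the expectation is only loosely anchored. A moderate rise in the number is expected in this assay, probably beyond the scatter, with an estimated 3.1-fold higher number from compound 1 to compound 3 (0.49 log units; beyond the scatter). That rise is expected to leave compound 3 with a lower number than compound 2, which gives 1080 nM. For compound 3 the estimated value is 170 nM, with an expected range of 45 nM to 650 nM.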

Compound 3, half-maximal inhibitory concentration: 82.6 nM
Estimate against measurement, compound 3: 2.1-fold (0.31 log units) above, within the range that was stated.
By their numbers in this assay, from the lowest: compounds 1 and 3 (each within the scatter of the next); then compound 2.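

At this aromatic carbon of the shared core, 4-hydroxyphenyl in place of 3,4-difluorophenyl gives a 1.5-fold higher number from compound 1 to compound 3 (0.17 log units; within the scatter) in this assay. Going by these compounds alone, the earlier pair showed only that the aryl group at this position can go with very different numbers; this step shows that the fluorines of compound 1 can be exchanged for a ring carrying a hydrogen-bond donor and acceptor without a shift beyond the scatter. Nothing available accounts for the size of this step.

Open, from the compounds shown here alone, is whether the hydroxyl matters on its own, which an unsubstituted phenyl or a methoxyphenyl would test, and whether a carboxylic acid or an amine on this ring would stay with compound 1 and compound 3 or fall nearer compound 2. The contribution of either fluorine alone also remains unresolved.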